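Aromatic azole in place of a saturated ring on sulfur

The source may hold more compounds than are shown below. What is called first, only, known or untested is meant among the compounds shown, and "the series" means these compounds.

The three measured compounds, with their results in a functional assay on MCF7 cells (Homo sapiens) for cytotoxicity, read by MTT assay, with a stated time of 24 h, tested at 16 ug/mL; a lower number here means a weaker effect, a higher number a stronger effect of the compound at the concentration tested:

Compound 1, `Cn1cnnc1SCC(=O)Nc1ccc(-c2nc(-c3ccccc3)c(-c3ccccc3)n2C)cc1`, gives 61.2%.
Compound 2, `Cc1nnc(SCC(=O)Nc2ccc(-c3nc(-c4ccccc4)c(-c4ccccc4)n3C)cc2)s1`, gives 74.9%.
Compound 3, `Cn1c(-c2ccc(NC(=O)CSC3=NCCS3)cc2)nc(-c2ccccc2)c1-c1ccccc1`, gives 41.8%.

Compound 3 stands lowest of the three in this assay; compound 1 lies nearest to it, compound 2 furthest, and both gaps lie beyond the scatter. Compound 4, `Cn1ccnc1SCC(=O)Nc1ccc(-c2nc(-c3ccccc3)c(-c3ccccc3)n2C)cc1`, has not been measured. It differs from compound 3 only on the sulfur whose other neighbour is a saturated chain carbon: a group of 6 heavy atoms (4 carbon, 2 nitrogen; one five-membered aromatic ring with 2 hetero atoms) in place of a group of 5 heavy atoms (3 carbon, 1 nitrogen, 1 sulfur; one five-membered non-aromatic ring with 2 hetero atoms), on a sulfur.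

Within the data shown here, two measured steps bear on this change, since each exchanges the same non-aromatic ring of compound 3 for a five-membered aromatic ring on that sulfur. Taken in the direction toward compound 3, they were a number 19.4 percentage points lower from compound 1 to compound 3 (beyond the scatter) and a number 33.1 percentage points lower from compound 2 to compound 3 (beyond the scatter). Both therefore show the aromatic ring paired with the higher number. Among the measured compounds shown here, the ring entering compound 4 is aromatic but carries two hetero atoms rather than three, so no measured step matches it exactly; still, the direction is consistent. Compound 4 is therefore expected to give a higher number than compound 3, by a step estimated as a number 20.2 percentage points higher from compound 3 to compound 4 (beyond the scatter). In this assay compound 4 is estimated at 62%, within a range from 48% to 78%.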

Compound 4, a percentage reported as activity, at one concentration (the size of the read-out at that concentration, not a potency): 32.4%
Estimate against measurement, compound 4: 29.6 percentage points above; measured number outside the range, below it.
By their numbers in this assay, from the lowest: compounds 4 and 3 (each within the scatter of the next); then compound 1; then compound 2.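

The aromatic character of the ring on a sulfur whose other neighbour is a saturated chain carbon does not by itself go with the higher number in this assay: 1-methyl-1H-imidazol-2-yl in that place gives a result (a number 9.4 percentage points lower from compound 3 to compound 4 (within the scatter)) that cannot be told apart from that of the saturated ring. The aromatic rings also separate sharply from one another, with a number 42.5 percentage points lower from compound 2 to compound 4 (beyond the scatter) and a number 28.8 percentage points lower from compound 1 to compound 4 (beyond the scatter), so compound 4 goes against the pairing of aromatic ring and higher number seen in compound 1 and compound 2, and the identity of the aromatic ring matters at this position. No measured evidence accounts for this split among the aromatic rings.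

Going by these compounds, it remains open whether an amine or a longer chain in place of the methyl on the 5-methyl-1,3,4-thiadiazol-2-yl group would keep the number of compound 2. On these data alone, it is also open whether these gaps would hold at other concentrations, as each result is a single reading at one concentration and gives no potency.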